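Working notes: a cyano group on the shared core

The compounds below may be only part of what the source reports. "The series", "measured", "known", "first", "only" and "open" are said of these compounds alone.

Measured in an ADME assay on HEp-2 cells (Homo sapiens) for cytotoxicity; a lower number here means that less compound is tolerated, a higher number that more compound is tolerated:
- Compound 1 `C=C(C)n1c(=O)n(Cc2nc3ccccc3n2CCC(C)C)c2ccccc21`: 24600 nM
- Compound 2 `C=C(C)n1c(=O)n(Cc2nc3cc(/C(N)=N\O)ccc3n2CCC(C)C)c2ccccc21`: 3470 nM
- Compound 3 `C=C(C)n1c(=O)n(Cc2nc3cc(C#N)ccc3n2CCC(C)C)c2ccccc21`: not yet measured

Compound 2 holds the lower of the two numbers in this assay, with 3470 nM against the higher number of compound 1. Compound 3 differs from compound 2 at one place: a group of 2 heavy atoms (1 carbon, 1 nitrogen; no ring) in place of a group of 4 heavy atoms (1 carbon, 2 nitrogen, 1 oxygen; no ring), on an aromatic carbon.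

For the measured compounds named here, one measured step bears on this change: a 7.1-fold lower number from compound 1 to compound 2 (0.85 log units; beyond the scatter). That step introduced the same group that compound 3 gives up. Going by the values given here, no measured compound carries a cyano group, so its own contribution is unknown. A partial return towards compound 1, with 24600 nM, is therefore expected rather than a full one. The expected change is modest and upward, a 2.9-fold higher number from compound 2 to compound 3 (0.46 log units; beyond the scatter). For compound 3 the estimated value is 10000 nM, with an expected range of 3500 nM to 30000 nM.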

Compound 3, half-maximal cytotoxic concentration: 1480 nM
For compound 3 the middle estimate is 6.8-fold (0.83 log units) above the measured one; measured number below the stated range.
By their numbers in this assay, from the lowest: compound 3; then compound 2; then compound 1.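

In this assay, cyano in place of hydrogen on the aromatic carbon lowers the number more than the four-atom group did (a 17-fold lower number from compound 1 to compound 3 (1.22 log units; beyond the scatter)), and exchanging that group for cyano lowers it further (a 2.3-fold lower number from compound 2 to compound 3 (0.37 log units; beyond the scatter)). The position therefore tolerates a change away from hydrogen only at a lower number in both listed cases, and this fall does not require hydrogen-bond donors on the entering group, as cyano has none. Nothing available accounts for the fall with either group.

As far as these compounds go, whether an amine or a carboxylic acid on this aromatic carbon would also lower the number, or bring it back towards that of compound 1, remains open. Also open, from the compounds shown here alone, is whether the cyano step keeps its size when the shared core carries a shorter chain elsewhere.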